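This account rests on a few compounds, and the source may have more. Where it says the series, first, only, none or still open, it means among the compounds named here.

Measured so far:
compound 1 `Cc1nc(-c2ccc(C(F)(F)F)cc2)sc1CNc1ccc(CC(=O)O)cc1`; in a functional assay on CHO cells for agonist activity at Free fatty acid receptor 1 (Homo sapiens) (a higher number here means that more compound is needed for the effect, a lower number that less compound is needed), compound 1 gives < 10000 nM, which is a limit of the assay and not a number.
compound 2 `O=C(O)CCCc1ccc(NCc2cccc(Oc3ccccc3)c2)cc1`; in this assay compound 2 gives 1120 nM.

Within the data shown here, compound 2 stands as the only number in this assay among the two measured compounds; the other value shown is a limit, as the limit of < 10000 nM in this assay, at which 1 of the 2 values shown sits, records. Among the measured compounds shown here, no step between measured compounds that differ in one place is available, so the usual size of a single change cannot be read from the measured data.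

Compound 3 `CNC(=O)CCc1ccc(NCc2cccc(Oc3ccccc3)c2)cc1` differs from compound 2 in one place: methylcarbamoyl in place of carboxymethyl on a saturated chain carbon, two bonds along the chain from an aromatic carbon. The change leaves the shared core and the rest of the chain untouched. In this assay compound 3 is expected to need more compound, with the step of a 5.4-fold higher number from compound 2 to compound 3 (0.73 log units; beyond the scatter) expected to exceed the scatter. The estimate for compound 3 in this assay is 6000 nM, with a range from 1500 nM to 30000 nM; a reading that returns only a limit is a real possibility.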

Compound 3, half-maximal effective concentration: 49 nM
Compound 3: the middle estimate sits 120-fold (2.09 log units) above what was measured, and the stated range ends above it.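

In this assay, among these compounds, the saturated chain carbon two bonds along the chain from an aromatic carbon proves to be a place where the end group has a strong bearing on the read-out: methylcarbamoyl in place of carboxymethyl gives a 23-fold lower number from compound 2 to compound 3 (1.36 log units; beyond the scatter) as the first single-place step, and a large one. Read one bond further out as 3-carboxypropyl to 2-(methylcarbamoyl)ethyl, the same pair shows that on this shared core a carboxyl group at the chain end is not needed for a low number in this assay. Nothing at hand bears on why the step is this large.

From the compounds shown here alone, it remains open whether the carbonyl, the amide hydrogen or the methyl carries the difference, a question that a primary carboxamide, a dimethylcarbamoyl group or an ethylcarbamoyl group at this place would help to separate. Also open, going by these compounds, are whether a longer chain leading to the methylcarbamoyl group keeps the low number and whether the same exchange carries over to the core of compound 1.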